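The source may hold more compounds than are shown below. What is called first, only, known or untested is meant among the compounds shown, and "the series" means these compounds.

Of the compounds shown here, three sharing one core have been measured in a functional assay, read by spectrophotometry, with a stated time of 2 h, tested at 3 mg/mL; a lower number here means a weaker effect, a higher number a stronger effect of the compound at the concentration tested. Compound 1 `CC(C)[C@@H]1CC[C@@H](C)C[C@@]12N(C)C(=O)[C@@H]1[C@H]3C(=O)NC(=O)[C@H]3ON12` carries hydrogen on the amide-type nitrogen in a ring, and in this assay compound 1 gives 72%. Compound 2 `CC(C)[C@@H]1CC[C@@H](C)C[C@@]12N(C)C(=O)[C@@H]1[C@H]3C(=O)N(c4ccccc4)C(=O)[C@H]3ON12` carries phenyl there, and compound 2 gives 73.5%. Compound 3 `CC(C)[C@@H]1CC[C@@H](C)C[C@@]12N(C)C(=O)[C@@H]1[C@H]3C(=O)N(c4ccc(Cl)cc4)C(=O)[C@H]3ON12` carries 4-chlorophenyl, and compound 3 gives 74%. Its number is the largest of the three, yet each step leading to it lies within the scatter: a number 1.5 percentage points higher from compound 1 to compound 2 (within the scatter), a number 2 percentage points higher from compound 1 to compound 3 (within the scatter) and a number 0.5 percentage points higher from compound 2 to compound 3 (within the scatter).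

Compound 4 `COc1ccc(N2C(=O)[C@H]3[C@H](ON4[C@@H]3C(=O)N(C)[C@@]43C[C@H](C)CC[C@H]3C(C)C)C2=O)cc1` differs from compound 3 in one place: methoxy in place of chloro on an aromatic carbon. The measured step bearing most directly on this change is the one in which chloro replaced hydrogen on an aromatic carbon, a number 0.5 percentage points higher from compound 2 to compound 3 (within the scatter). The two steps from compound 1 likewise show that placing phenyl or 4-chlorophenyl on the amide-type nitrogen left this assay essentially unchanged. Among the compounds with values here, no measured compound carries methoxy, so that group itself has no precedent here. Because a number 0.5 percentage points higher from compound 2 to compound 3 (within the scatter) stayed within the scatter, compound 4 is expected to give 73.5%, with a range from 65% to 82%. The estimated step is therefore a number 0.5 percentage points lower from compound 3 to compound 4 (within the scatter), no more than the scatter.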

Compound 4, a percentage reported as activity, at one concentration (the size of the read-out at that concentration, not a potency): 75.1%
Estimate against measurement, compound 4: 1.6 percentage points below; the measured number falls inside the stated range.
By their numbers in this assay, from the lowest: compounds 1, 2, 3 and 4 (each within the scatter of the next).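

In this assay, methoxy in place of chloro on this aromatic carbon, para to a large group, adds a hydrogen-bond acceptor where chloro has none, yet the step is a number 1.1 percentage points higher from compound 3 to compound 4 (within the scatter) and no more. Methoxy in place of hydrogen on the same carbon gives a number 1.6 percentage points higher from compound 2 to compound 4 (within the scatter), and 4-methoxyphenyl in place of hydrogen on the amide-type nitrogen gives a number 3.1 percentage points higher from compound 1 to compound 4 (within the scatter), so hydrogen, chloro and methoxy at this position, and all of the groups tried on the nitrogen, remain inseparable across compound 1, compound 2, compound 3 and compound 4, with none going against this. Nothing available explains why the read-out stays so level across these changes.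

The compounds shown leave open whether any other group on this aromatic carbon, such as an amine or a carboxylic acid, would move the read-out beyond the scatter. They also leave open whether a longer chain or a benzyl group on the amide-type nitrogen, in place of the aromatic ring, would do so, and how these compounds would compare at other concentrations.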